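The source may report more compounds than this note shows. Statements on the series, on what has been measured and on what is new or still open speak of the compounds shown alone.

Compound 1 `COc1cc(C(=O)Cl)c(OC)c(OC)c1OC` opens the series. In a functional assay on cells (Neutrophil, Homo sapiens) for inhibition (a higher number here means a weaker inhibitor, a lower number a stronger inhibitor), compound 1 reaches only a limit, > 100000 nM. Among the compounds with values here, compound 2 `C=C(C)C#Cc1c(OC)cc(OC)c(OC)c1C` supplies the only actual number: in this assay compound 2 gives 9330 nM. Compound 3 `COc1cc(OC)c(OC)c(C)c1C#CC(C)=O` differs by acetyl in place of 1-methylethenyl on a triple-bonded carbon. Within the data shown here, no measured step between two numbered compounds exists, so no precedent for the size of this change is available. The step is expected to be modest, a 1.3-fold higher number from compound 2 to compound 3 (0.11 log units; within the scatter), with no direction that clearly exceeds the scatter. Compound 3 is estimated at 12000 nM, within a range of 3000 nM to 45000 nM.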

Compound 3, half-maximal inhibitory concentration: > 100000 nM
Compound 3: only a limit was reported; the forecaster's own chance of this, stated with the estimate: 10%; middle value at least 8.3-fold (0.92 log units) away from the limit.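

On the triple-bonded carbon, acetyl in place of 1-methylethenyl gives an at least 10-fold higher number from compound 2 to compound 3 (1.03 log units; beyond the scatter) in this assay, so this position responds strongly to a swap of two groups with the same count of heavy atoms. Compound 3 has only a limit, > 100000 nM. The step therefore shows a minimum and not a full size: the limit of > 100000 nM in this assay, at which 2 of the 3 values shown sit.

Still open, from the compounds shown here alone, is whether the carbonyl oxygen of acetyl or the absence of 1-methylethenyl drives the loss. A propyl chain or an amine on the same triple-bonded carbon would bear on that.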